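The source may report more compounds than this note shows. Statements on the series, on what has been measured and on what is new or still open speak of the compounds shown alone.

Compound 1 `Cc1c(C)c2ccc(OCC3CCN(Cc4ccc(CO)cc4)CC3)cc2oc1=O` gives 1400 nM in an assay for inhibition of Amine oxidase [flavin-containing] A (Homo sapiens), read by fluorescence, using microsomes, with a stated time of 30 min; a higher number here means a weaker inhibitor, a lower number a stronger inhibitor.
Compound 2 `Cc1c(C)c2ccc(OCC3CCN(Cc4cccc(CO)c4)CC3)cc2oc1=O` gives 1900 nM in this assay.

Compound 2 stands alongside compound 1 rather than apart from it: the step of a 1.4-fold higher number from compound 1 to compound 2 (0.13 log units; within the scatter) does not exceed the scatter of repeated measurement, so the two numbers cannot be told apart. Compound 3 `Cc1c(C)c2ccc(OCC3CCN(Cc4ccc(CCO)cc4)CC3)cc2oc1=O` has not yet been measured. It differs from compound 2 in one place: 4-(2-hydroxyethyl)phenyl in place of 3-(hydroxymethyl)phenyl on a saturated chain carbon bound to an amine nitrogen in a ring. For the measured compounds named here, the only measured step that speaks to this change is the one from compound 1 to compound 2, which moved the same hydroxymethyl group around the ring and gave a 1.4-fold higher number from compound 1 to compound 2 (0.13 log units; within the scatter), a change within the scatter. Nothing in the data shows that lengthening the chain by one carbon matters, so the step of a 1.3-fold lower number from compound 2 to compound 3 (0.10 log units; within the scatter) is expected to be small, with no clear direction. Compound 3 is therefore estimated at 1500 nM, within a range from 600 nM to 4000 nM.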

Compound 3, half-maximal inhibitory concentration: 1700 nM
Beside the measured number, compound 3's estimate is 1.1-fold (0.05 log units) below it; the range from low to high includes it.
By their numbers in this assay, from the lowest: compounds 1, 3 and 2 (each within the scatter of the next).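

Lengthening the chain by one carbon, with hydroxymethyl in place of hydroxy on a saturated chain carbon bound to an aromatic carbon, gives a 1.2-fold higher number from compound 1 to compound 3 (0.08 log units; within the scatter) in this assay, so this small extension cannot be told apart from no change. The step that changes both chain length and ring placement at once, 4-(2-hydroxyethyl)phenyl in place of 3-(hydroxymethyl)phenyl, gives a 1.1-fold lower number from compound 2 to compound 3 (0.05 log units; within the scatter), which leaves all three compounds within the scatter of one another. No outside evidence bears on this result.

Going by these compounds, it remains open whether an amine or a carboxylic acid in place of the hydroxy, or a much longer chain, would move the number beyond the scatter. A plain benzyl group would show whether the hydroxy matters at all.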